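This account rests on a few compounds, and the source may have more. Where it says the series, first, only, none or still open, it means among the compounds named here.

In a physicochemical assay for solubility, read by LC-MS, with a stated time of 16 h, at pH 7 (on this read-out higher numbers stand for higher solubility and lower numbers for lower solubility), compound 1 `COCCC[S+]([O-])c1sc2nc(-c3nccs3)cc(-c3cnc(C)n3C)c2c1N` gives 115 ug/mL, and compound 2 `CCCC[S+]([O-])c1sc2nc(-c3nccs3)cc(-c3nccs3)c2c1N` gives 0.3 ug/mL, the lower of the two numbers and well beyond the scatter. Compound 3 `CCCC[S+]([O-])c1sc2nc(-c3nccs3)cc(-c3cnc(C)[nH]3)c2c1N` departs from compound 2 at one place, opposite the ring nitrogen: 2-methyl-1H-imidazol-5-yl in place of 1,3-thiazol-2-yl on an aromatic carbon. For the measured compounds named here, no measured pair isolates this change, so the only guide is compound 1 at 115 ug/mL, which carries a related group there but differs elsewhere too. The expected step of a 67-fold higher number from compound 2 to compound 3 (1.82 log units; beyond the scatter) is upward and beyond the scatter. For compound 3 the estimated value is 20 ug/mL, with an expected range of 3 ug/mL to 100 ug/mL.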

Compound 3, solubility: 4.1 ug/mL
For compound 3 the middle estimate is 4.9-fold (0.69 log units) above the measured one; low and high end bracket the measured number.
By their numbers in this assay, from the lowest: compound 2; then compound 3; then compound 1.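

In this assay, the position opposite the ring nitrogen now has a single-change comparison: 2-methyl-1H-imidazol-5-yl in place of 1,3-thiazol-2-yl gives a 14-fold higher number from compound 2 to compound 3 (1.14 log units; beyond the scatter) with the rest of the molecule unchanged. This large upward step belongs to that change alone, whereas compound 1 differs from compound 2 elsewhere too. No measurement here speaks to the reason for the step. Still open, as far as these compounds go, is how an amine or a carboxylic acid on this aromatic carbon would read, and whether a step of this size would recur with the chain of compound 1.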